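This account rests on a few compounds, and the source may have more. Where it says the series, first, only, none or still open, it means among the compounds named here.

In an ADME assay on a cell-free system (plasma, Mus musculus) for metabolic stability, read by LC-MS, tested at 2 uM (on this read-out lower numbers stand for a shorter-lived compound and higher numbers for a longer-lived compound), three compounds sharing one core have been measured, and they differ in the chain on the amide-type nitrogen. Compound 1 `O=C(NCCCCc1ccccc1)n1cc(-c2ccccc2)oc1=O`, whose chain ends in phenyl, gives < 0.0834 h, which is a limit of the assay and not a number. Compound 2 `CCCCCNC(=O)n1cc(-c2ccccc2)oc1=O`, with a plain pentyl chain, gives > 2 h, which is also a limit and not a number. Compound 3 `CCOCCNC(=O)n1cc(-c2ccccc2)oc1=O`, with an ethoxy-bearing chain, gives 1.33 h.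

Two large steps stand out: an at least 23-fold higher number from compound 1 to compound 2 (1.37 log units; beyond the scatter), and an at least 15-fold higher number from compound 1 to compound 3 (1.20 log units; beyond the scatter). Both lose the phenyl, and compound 2 has no phenyl to lose, so neither step carries over directly.

Compound 4 `CC(C)CNC(=O)n1cc(-c2ccccc2)oc1=O` has not yet been measured. Its difference from compound 2 is isopropyl in place of butyl on a saturated chain carbon bound to an amide-type nitrogen: pentyl to isobutyl, with no ring entering. The closest guide is a chain change that also involves no phenyl: an at least 1.5-fold lower number from compound 2 to compound 3 (0.17 log units; that floor lies within the scatter).

No step beyond the scatter is therefore expected, in either direction. The expected step is a number no higher from compound 2 to compound 4 (the limit leaves the size open). For compound 4 the estimated half-life is 2 h, with an expected range from 1 h to 4 h. The assay may well report only a limit again.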

Compound 4, half-life: > 2 h
Compound 4: a limit, no number; the forecaster's own chance of this, stated with the estimate: 55%; the middle value sits exactly at the limit.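

In this assay, compound 4 with its isobutyl chain gives a limit, not a number, and it is the same limit as for compound 2 with its pentyl chain, so a chain with no ring stays at the long-lived end of the scale in both the pentyl and the isobutyl form. The change from pentyl to isobutyl itself cannot be read, because both compounds sit at one and the same limit, which hides any real difference between them: the limit of > 2 h in this assay, at which 2 of the 4 values shown sit. Among the compounds shown here, the one readable step is an at least 1.5-fold higher number from compound 3 to compound 4 (0.17 log units; that floor lies within the scatter), so the isobutyl chain of compound 4 and the ethoxy-bearing chain of compound 3 cannot be told apart here.

From the compounds shown here alone, what stays open is how long compound 2 and compound 4 really last beyond the limit, and so whether swapping pentyl for isobutyl matters at all in this assay. Also open, going by these compounds, is whether the short life of compound 1 goes with its phenyl ring or with something else about its chain, a question that a cyclohexyl group on the same butyl chain, or a longer plain chain such as octyl, could help to answer.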